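Cytotoxicity notes on the benzyl amide carbamate series

This account rests on a few compounds, and the source may have more. Where it says the series, first, only, none or still open, it means among the compounds named here.

Among the compounds with values here, compound 1 `COc1ccc(CNC(=O)c2nc(C(C)(C)NC(=O)OCc3ccccc3)nc(O)c2O)cc1` is the one member of this set with an actual number in an ADME assay on C8166 cells (Homo sapiens) for cytotoxicity, read by MTT assay, with a stated time of 3 days; a lower number here means that less compound is tolerated, a higher number that more compound is tolerated: compound 1 gives 164000 nM. Compound 2 `COc1ccc(CNC(=O)Nc2nc(C(C)(C)NC(=O)OCc3ccccc3)nc(O)c2O)cc1` stays at a limit of the assay, > 500000 nM. Compound 3 `CC(C)(NC(=O)OCc1ccccc1)c1nc(O)c2oc(=O)[nH]c2n1` likewise reports only a limit, > 500000 nM. Two of the three values therefore sit at the limit of > 500000 nM in this assay, at which 2 of the 3 values shown sit, so compound 1 stands alone as the sole numeric point. No pair of these compounds differs in a single place, so no measured step exists to lean on. Compound 4 `COc1cc(CNC(=O)c2nc(C(C)(C)NC(=O)OCc3ccccc3)nc(O)c2O)cc(OC)c1OC` is not yet measured; relative to compound 1 the change is 3,4,5-trimethoxyphenyl in place of 4-methoxyphenyl on a saturated chain carbon bound to an amide-type nitrogen. Without a comparable step in hand, the expected step is a 1.2-fold higher number from compound 1 to compound 4 (0.09 log units; within the scatter), nothing beyond the usual scatter. For compound 4 the estimate in this assay is 200000 nM, within a range of 60000 nM to 500000 nM.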

Compound 4, half-maximal cytotoxic concentration: 110000 nM
The estimate for compound 4 lay 1.8-fold (0.26 log units) above the measured number; measured number inside the range.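

With compound 4, this position on a saturated chain carbon bound to an amide-type nitrogen has its first readable step: in this assay, 3,4,5-trimethoxyphenyl in place of 4-methoxyphenyl gives a 1.5-fold lower number from compound 1 to compound 4 (0.17 log units; within the scatter). The two compounds cannot be told apart here, even with the larger group. Compound 4 also adds a second numeric point to a set otherwise held at a limit: the limit of > 500000 nM in this assay, at which 2 of the 4 values shown sit.

Still open, as far as these compounds go, is whether a phenyl group carrying an amine or a carboxylic acid in place of the methoxy groups would move the number beyond the scatter.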